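The source may hold more compounds than are shown below. What is called first, only, known or untested is meant among the compounds shown, and "the series" means these compounds.

In an assay on isolated protein for binding affinity to melatonin receptor type 1B (Homo sapiens) (on this read-out higher numbers stand for weaker inhibition and lower numbers for stronger inhibition), compound 1 `CCCC(=O)Nc1ccc(Oc2cccc(OC)c2)cc1` gives 0.75 nM, compound 2 `COc1cccc(Oc2ccc(NC(=O)C3CC3)cc2)c1` gives 13 nM and compound 3 `C/C=C/C(=O)Nc1ccc(Oc2cccc(OC)c2)cc1` gives 2.1 nM, so compound 3 holds the second highest of the three numbers, closest to compound 1. Compound 4 `CCNC(=O)Nc1ccc(Oc2cccc(OC)c2)cc1` differs from compound 3 only at the carbonyl carbon: ethylamino in place of prop-1-en-1-yl on a carbonyl carbon. All three measured steps also changed the group on this carbonyl carbon and all moved the number beyond the scatter: a 17-fold higher number from compound 1 to compound 2 (1.24 log units; beyond the scatter), a 2.8-fold higher number from compound 1 to compound 3 (0.45 log units; beyond the scatter) and a 6.2-fold lower number from compound 2 to compound 3 (0.79 log units; beyond the scatter). None of them introduced a nitrogen there, so the size remains uncertain, but a change beyond the scatter, most likely towards a higher number, is expected, a 4.8-fold higher number from compound 3 to compound 4 (0.68 log units; beyond the scatter). Compound 4 is therefore estimated at 10 nM, within a range of 2 nM to 60 nM.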

Compound 4, inhibition constant: 250 nM
Compound 4: middle estimate off by 25-fold (1.40 log units), on the low side; the whole stated range lies below it.
By their numbers in this assay, from the lowest: compound 1; then compound 3; then compound 2; then compound 4.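

In this assay the ethylamino group on the carbonyl carbon gives the highest number of the series, whichever group it replaces: prop-1-en-1-yl (a 120-fold higher number from compound 3 to compound 4 (2.08 log units; beyond the scatter)), cyclopropyl (a 19-fold higher number from compound 2 to compound 4 (1.28 log units; beyond the scatter)) or propyl (a 330-fold higher number from compound 1 to compound 4 (2.52 log units; beyond the scatter)). Ethylamino has the same heavy-atom count as prop-1-en-1-yl but carries a nitrogen and a hydrogen-bond donor, so matching that count alone does not keep the number low here. Nothing available explains this jump. Going by these compounds, whether the nitrogen or the ethyl part matters remains open: methylamino or ethoxy on this carbonyl carbon could help separate the two.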